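Series notes: thioether in place of ether at the shared core

This account rests on a few compounds, and the source may have more. Where it says the series, first, only, none or still open, it means among the compounds named here.

compound 1, `Nc1cc(N)c2nc(-c3ccccc3)c(Oc3ccc(F)cc3)nc2c1`: < 100000 nM
compound 2, `COc1cc(CNc2nc3cc(N)cc(N)c3nc2-c2ccccc2)cc(OC)c1OC`: < 50200 nM
compound 3, `CCOC(=O)[C@H](CCC(=O)O)NC(=O)c1ccc(Oc2nc3cc(N)cc(N)c3nc2-c2ccccc2)cc1`: < 100000 nM

In a functional assay on SK-MEL-2 cells (Homo sapiens) for inhibition, read by sulforhodamine B assay, with a stated time of 48 h (a lower number here means a stronger inhibitor of growth, a higher number a weaker inhibitor of growth), compound 1 gives < 100000 nM, which is a limit of the assay and not a number. Compound 2 gives < 50200 nM, also a limit. Compound 3 gives < 100000 nM, a limit as well. Compound 1 therefore has no position on a scale: only a limit is known for it, as for the other two (the limit of < 100000 nM in this assay, at which 2 of the 3 values shown sit; (the limit of < 50200 nM in this assay, at which 1 of the 3 values shown sits)). Compound 4, `COc1ccc(Sc2nc3cc(N)cc(N)c3nc2-c2ccccc2)cc1`, carries (4-methoxyphenyl)sulfanyl in place of 4-fluorophenoxy on an aromatic carbon. Among the compounds with values here, no step between measured compounds exists to lean on. The step from compound 1 to compound 4 in this assay is expected to be a step that the limit leaves unreadable from compound 1 to compound 4, with no clear direction and probably none beyond the scatter. Compound 4 is estimated at 60000 nM, between 10000 nM and 200000 nM.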

Compound 4, concentration for total growth inhibition: < 100000 nM
Compound 4 ended at the assay's limit; the forecaster's own chance of this, stated with the estimate: 70%; the middle value does not contradict the limit.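

Within the data shown here, compound 1 and compound 4 both give only a limit in this assay, not a number, so no step between them can be read. The compounds shown leave open whether (4-methoxyphenyl)sulfanyl in place of 4-fluorophenoxy changes growth inhibition at all, or by how much: the limit of < 100000 nM in this assay, at which 3 of the 4 values shown sit.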